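The source may report more compounds than this note shows. Statements on the series, on what has been measured and on what is new or still open speak of the compounds shown alone.

The measured compounds:
Compound 1 `CC(C)(C)n1cc2c(n1)C(=O)CC1(CCN(C(=O)c3cc(-c4ccccc4)nc4ccccc34)CC1)O2` gives > 10000 nM in a functional assay on MDA-MB-231 cells (Homo sapiens) for inhibition, read by MTT assay, with a stated time of 72 h (a lower number here means a stronger inhibitor, a higher number a weaker inhibitor), a limit of the assay.
Compound 2 `CC(C)(C)n1cc2c(n1)C(=O)CC1(CCN(C(=O)c3cc(-c4ccccc4Cl)nc4ccccc34)CC1)O2` gives > 10000 nM in this assay, likewise a limit.
Compound 3 `CC(C)(C)n1cc2c(n1)C(=O)CC1(CCN(C(=O)c3cc(-c4ccncc4)nc4ccccc34)CC1)O2` gives 1650 nM in this assay.

Compound 2 therefore stands at the limit of > 10000 nM in this assay, at which 2 of the 3 values shown sit, and no number of its own is known for it. The step from compound 1 to compound 2, a step that the two limits leave unreadable from compound 1 to compound 2, cannot be read either. For the measured compounds named here, the only readable step that starts from compound 2 is an at least 6.0-fold lower number from compound 2 to compound 3 (0.78 log units; beyond the scatter), and the parallel step an at least 6.0-fold lower number from compound 1 to compound 3 (0.78 log units; beyond the scatter) is of the same size; both exchange one six-membered aromatic ring for another that carries a ring nitrogen.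

Compound 4 `CCOc1cc(C(=O)N2CCC3(CC2)CC(=O)c2nn(C(C)(C)C)cc2O3)c2ccccc2n1` differs from compound 2 in one place: ethoxy in place of 2-chlorophenyl on an aromatic carbon. Going by the values given here, no measured step exchanges a ring for a short chain in this way, so the two readable steps bear on it only loosely: they show that replacing the 2-chlorophenyl can bring the number down out of the limit. With the ring removed altogether, the outcome is uncertain.

For compound 4 the number in this assay is expected to lie around 5000 nM, within 1500 nM to 20000 nM; the expected step of an at least 2.0-fold lower number from compound 2 to compound 4 (0.30 log units; that floor lies within the scatter) is therefore at best modest, with a fair chance that only a limit is reported again.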

Compound 4, half-maximal inhibitory concentration: > 10000 nM
Compound 4 was reported as a limit; the forecaster's own chance of this, stated with the estimate: 45%; at least 2.0-fold (0.30 log units) between middle value and limit.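

In this assay compound 4 ends at a limit and not at a number, the same limit as compound 2: the limit of > 10000 nM in this assay, at which 3 of the 4 values shown sit. The steps among compound 1, compound 2 and compound 4 cannot be read, so these compounds do not tell whether ethoxy, phenyl and 2-chlorophenyl differ from one another on this aromatic carbon next to the ring nitrogen. The one readable new step is an at least 6.0-fold higher number from compound 3 to compound 4 (0.78 log units; beyond the scatter), and it adds what the earlier compounds could not show: exchanging the aromatic ring for a short chain does not by itself bring the number out of the limit, so that among the four groups shown only pyridin-4-yl gives a number of its own.

Going by these compounds, it remains open whether the placing of the ring nitrogen matters, as pyridin-3-yl or pyridin-2-yl would show. Also open, on these data alone, is whether a chain or a non-aromatic group on this carbon can give a number of its own at all, for instance an amine such as dimethylamino, a longer chain such as butoxy, or a morpholine ring.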